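Swapping a chlorinated chain that sits at the assay limit

The compounds below may be only part of what the source reports. "The series", "measured", "known", "first", "only" and "open" are said of these compounds alone.

- compound 1 `CC(Cl)C(=O)Nc1ccc(C2=NNC(=O)CC2)cc1`: 0.45 ug/mL
- compound 2 `O=C1CCC(c2ccc(NC(=O)CCCl)cc2)=NN1`: 0.98 ug/mL
- compound 3 `O=C1CCC(c2ccc(NC(=O)CCCCl)cc2)=NN1`: > 46.4 ug/mL

In a functional assay for inhibition, with Homo sapiens as the target (on this read-out higher numbers stand for an effect only at larger amounts of compound and lower numbers for an effect already at smaller amounts), these three compounds share a core and differ only in the chlorinated group on a carbonyl carbon. Compound 3 stands at the limit of > 46.4 ug/mL in this assay, at which 1 of the 3 values shown sits. That is a limit and not a number.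

The next compound, compound 4 `CC(C)(CCl)C(=O)Nc1ccc(C2=NNC(=O)CC2)cc1`, exchanges this group: 1-(chloromethyl)-1-methylethyl in place of 3-chloropropyl on a carbonyl carbon. Put simply, 1-(chloromethyl)-1-methylethyl comes in place of 3-chloropropyl on a carbonyl carbon.

Going by the values given here, three measured steps bear on this change. The first, a 2.2-fold higher number from compound 1 to compound 2 (0.34 log units; beyond the scatter), is only modest. The other two, an at least 100-fold higher number from compound 1 to compound 3 (2.01 log units; beyond the scatter) and an at least 47-fold higher number from compound 2 to compound 3 (1.67 log units; beyond the scatter), are both large, and both end at the 3-chloropropyl group. Among these three compounds, then, the large loss comes only with that group, which compound 4 no longer carries. By its name, the entering group resembles the 2-chloroethyl of compound 2 at 0.98 ug/mL more than it resembles 3-chloropropyl. Among the compounds with values here, no measured compound carries this exact group, so the expectation stays broad.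

The expected change is an at least 15-fold lower number from compound 3 to compound 4 (1.18 log units; beyond the scatter), a large step towards a lower number. For compound 4 the estimated value is 3 ug/mL, with an expected range from 0.4 ug/mL to 30 ug/mL.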

Compound 4, half-maximal effective concentration: 11.4 ug/mL
Compound 4: middle estimate off by 3.8-fold (0.58 log units), on the low side; the measured number falls inside the stated range.
By their numbers in this assay, from the lowest: compound 1; then compound 2; then compound 4. At a limit, above all of these: compound 3.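

In this assay, 1-(chloromethyl)-1-methylethyl on the carbonyl carbon wins back part of what 3-chloropropyl gave up, with an at least 4.0-fold lower number from compound 3 to compound 4 (0.60 log units; beyond the scatter). As far as these compounds go, compound 3 has only a limit and not a number, so the true size of this step stays unknown: the limit of > 46.4 ug/mL in this assay, at which 1 of the 4 values shown sits. The recovery is only partial, with a 12-fold higher number from compound 2 to compound 4 (1.07 log units; beyond the scatter) and a 25-fold higher number from compound 1 to compound 4 (1.40 log units; beyond the scatter), so among these four compounds a large rise in the number no longer comes with 3-chloropropyl alone, and the two smaller groups, 1-chloroethyl and 2-chloroethyl, keep the lowest numbers.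

Every group shown carries a chlorine, so it remains open how a plain propyl chain without chlorine would read in this assay. Also open, from the compounds shown here alone, is how a 2-bromoethyl or a 2-aminoethyl group on the same carbonyl carbon would compare with the 2-chloroethyl group of compound 2, which gives 0.98 ug/mL.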